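Swapping methoxy for hydroxymethyl on a well-tolerated compound

The source may hold more compounds than are shown below. What is called first, only, known or untested is meant among the compounds shown, and "the series" means these compounds.

In an ADME assay on cells (Peritoneal macrophage, Mus musculus, strain Balb/c) for cytotoxicity, read by resazurin assay, with a stated time of 72 h (a higher number here means that more compound is tolerated, a lower number that less compound is tolerated), compound 1 `CC1(Cc2ccc(/C(N)=N/O)cc2)CC(S(=O)(=O)c2ccc(F)cc2)=C(c2ccc(/C(N)=N/O)cc2)O1` gives 42200 nM. Compound 2 `COc1ccc(CC2(C)CC(S(=O)(=O)c3ccc(F)cc3)=C(c3ccc(/C(N)=N/O)cc3)O2)cc1` reads > 100000 nM, which is a limit of the assay and not a number. Compound 3 `CC1(Cc2ccc(CO)cc2)CC(S(=O)(=O)c2ccc(F)cc2)=C(c2ccc(/C(N)=N/O)cc2)O1` has hydroxymethyl in place of methoxy on an aromatic carbon, para to a large group, and its atoms match those of compound 2 but are joined differently: hydroxymethyl in place of methoxy on an aromatic carbon. Among the measured compounds shown here, only one measured step changes a group on that aromatic carbon, an at least 2.3-fold higher number from compound 1 to compound 2 (0.37 log units; beyond the scatter). That step is open-ended and involves a different group, so it offers only a loose guide to size. A modest move towards a lower number is expected in this assay, and a reading at the limit remains possible. The estimated change is an at least 1.3-fold lower number from compound 2 to compound 3 (0.12 log units; that floor lies within the scatter). Compound 3 is expected at 75000 nM, with an estimated range from 30000 nM to 150000 nM.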

Compound 3, half-maximal cytotoxic concentration: > 100000 nM
Compound 3 ended at the assay's limit; the forecaster's own chance of this, stated with the estimate: 45%; middle value at least 1.3-fold (0.12 log units) away from the limit.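

In this assay, the change on this aromatic carbon again gives an at least 2.3-fold higher number from compound 1 to compound 3 (0.37 log units; beyond the scatter), so the higher number seen with methoxy is not tied to that one group. Hydroxymethyl has 1 hydrogen-bond donor and methoxy has 0, yet compound 2 and compound 3 both reach the assay's limit, while compound 1 stays measurable. The step between these two groups cannot be read, because each compound gives a limit and not a number: the limit of > 100000 nM in this assay, at which 2 of the 3 values shown sit.

From the compounds shown here alone, how much more compound the cells would tolerate in either case remains unknown, so any real difference between methoxy and hydroxymethyl stays hidden. Going by these compounds, it also remains open whether an amine, a carboxylic acid or a longer chain at this place would reach the limit too.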